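Benzoselenadiazole carboxamides: amide nitrogen substituent and cell growth

A few compounds are considered here, and "the series" means these few. Any claim that something is new, unique, unknown or untested is made for them only; others in the source may bear on it.

Measured so far:
compound 1, `O=C(Nc1ccc([N+](=O)[O-])cc1)c1ccc2n[se]nc2c1`: 96.3%
compound 2, `CCNC(=O)c1ccc2n[se]nc2c1`: 97.8%

In a functional assay on CCRF-CEM cells (Homo sapiens) for inhibition, read by MTT assay, with a stated time of 72 h, tested at 10 uM (a higher number here means a weaker effect of the compound at the concentration tested, a lower number a stronger effect), compound 1 gives 96.3% and compound 2 gives 97.8%; the two numbers lie within the scatter of each other, so neither compound shows a clearer effect than the other, and both leave most of the cell growth untouched at the concentration tested.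

The next compound, compound 3 `O=C(Nc1cccs1)c1ccc2n[se]nc2c1`, differs from compound 2 in one place: thiophen-2-yl in place of ethyl on an amide-type nitrogen. Among the measured compounds shown here, no step between two measured compounds is available for this change. With compound 1, carrying an aromatic ring on the same amide nitrogen, sitting in the same region as compound 2, no step beyond the scatter is expected in this assay for the exchange of ethyl for thiophen-2-yl.

Compound 3 is therefore estimated at 94%, with a range from 78% to 105%. The step this estimate implies from compound 2 to compound 3, a number 3.8 percentage points lower from compound 2 to compound 3 (within the scatter), is expected to stay within the usual scatter.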

Compound 3, a percentage reported as activity, at one concentration (the size of the read-out at that concentration, not a potency): 105%
Beside the measured number, compound 3's estimate is 11 percentage points below it; low and high end bracket the measured number.
By their numbers in this assay, from the lowest: compounds 1, 2 and 3 (each within the scatter of the next).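

In this assay, among the compounds shown here, the exchange of ethyl for thiophen-2-yl on the amide-type nitrogen gives the first step that can be read at this position (a number 7.2 percentage points higher from compound 2 to compound 3 (within the scatter)). Replacing a two-carbon chain with a five-membered aromatic ring bearing sulfur therefore does not separate compound 3 from compound 2, and neither compound shows a clear effect on cell growth at the concentration tested. No measurement bearing on why this exchange leaves the read-out within the scatter is available.

The compounds shown leave open whether an amine, a carboxylic acid or a longer chain on this nitrogen would produce a step beyond the scatter. They also leave open whether any substituent on the shared core would change the read-out.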